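Chain Extension on the Carboxamide of Compound 2

This account rests on a few compounds, and the source may have more. Where it says the series, first, only, none or still open, it means among the compounds named here.

Working notes on the series. In a functional assay, with a stated time of 60 min, tested at 0.1 mM (on this read-out higher numbers stand for a stronger effect at the one concentration tested and lower numbers for a weaker effect), compound 1 `COC(=O)c1c(O)c2ccccc2n(C)c1=O` gives 7.4%, compound 2 `Cn1c(=O)c(C(=O)NCCN)c(O)c2ccccc21` gives 11.5%, and compound 3 `NCCNC(=O)c1c(O)c2ccccc2n(-c2ccccc2)c1=O` gives 10%. Compound 2 stands at the top of the three numbers, with compound 3 nearest and compound 1 furthest, but both gaps fall within the scatter, so the three compounds are not told apart on this read-out. The two measured steps, a number 4.1 percentage points higher from compound 1 to compound 2 (within the scatter) and a number 1.5 percentage points lower from compound 2 to compound 3 (within the scatter), are likewise both within the scatter.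

Compound 4 `Cn1c(=O)c(C(=O)NCCCCCCN)c(O)c2ccccc21` differs from compound 2 in one place: 4-aminobutyl in place of amino on a saturated chain carbon, two bonds along the chain from an amide-type nitrogen. Neither measured step alters the length of the chain on the carboxamide, so none bears directly on this change; what they do show is that exchanges on the carbonyl carbon and on the aromatic nitrogen moved the read-out in this assay by no more than the scatter, with all three compounds remaining low. The step of a number 0.5 percentage points lower from compound 2 to compound 4 (within the scatter) is accordingly expected to stay within the scatter, in no particular direction. Compound 4 is estimated at 11%, with a range from 3% to 21%.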

Compound 4, a percentage reported as activity, at one concentration (the size of the read-out at that concentration, not a potency): 8.3%
Estimate against measurement, compound 4: 2.7 percentage points above; low and high end bracket the measured number.
By their numbers in this assay, from the lowest: compounds 1, 4, 3 and 2 (each within the scatter of the next).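

In this assay the exchange of amino for 4-aminobutyl, on a saturated chain carbon, two bonds along the chain from an amide-type nitrogen, gives a number 3.2 percentage points lower from compound 2 to compound 4 (within the scatter) and so adds the one step shown that alters chain length at this position. At this one concentration, 2-aminoethyl and 6-aminohexyl on the carboxamide are not told apart, so this added chain length has no effect that can be read beyond the scatter. Nothing shown gives a measured reason for this result.

Open, from the compounds shown here alone, is whether other chain lengths, such as 3-aminopropyl or a longer 8-aminooctyl chain, would read differently. Also open, going by these compounds, is whether a carboxylic acid or a dimethylamino group at the chain end would move the read-out beyond the scatter.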